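Methylating the thiol sulfur of compound 3

The compounds below may be only part of what the source reports. "The series", "measured", "known", "first", "only" and "open" are said of these compounds alone.

Compound 3 `Cc1ncc2cnnc(S)n12` carries a free thiol on the shared core. In a functional assay for inhibition, with Homo sapiens as the target (a lower number here means a stronger inhibitor, a higher number a weaker inhibitor), compound 3 gives only a limit, > 48000 nM. Compound 1 `COCc1ncc2cnnc(SC)n12` likewise gives only a limit in this assay, > 48000 nM. Compound 2 `C=CCSc1nncc2cnc(C)n12`, with an allyl on the sulfur, gives 61000 nM in this assay. The step that the limit leaves unreadable from compound 2 to compound 3 cannot be read, since the limit of > 48000 nM in this assay, at which 2 of the 3 values shown sit, hides its size. The unmeasured compound 4 `CSc1nncc2cnc(C)n12` differs from compound 3 by methyl in place of hydrogen on a sulfur. No readable step bears on this change, and every value shown is weak, so compound 4 is expected to remain weak, with a step that the limit leaves unreadable from compound 3 to compound 4 that is not expected to exceed the scatter. Compound 4 is therefore estimated at 60000 nM, within 25000 nM to 150000 nM.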

Compound 4, half-maximal inhibitory concentration: > 48000 nM
Compound 4: no number, only a limit; the forecaster's own chance of this, stated with the estimate: 60%; the middle value is on the limit's open side.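

The steps from compound 1, compound 2 and compound 3 to compound 4 cannot be read, because they rest on a limit: the limit of > 48000 nM in this assay, at which 3 of the 4 values shown sit.

The compounds shown leave open whether the group on the sulfur of the shared core affects inhibition at all.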